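The compounds below may be only part of what the source reports. "The series", "measured", "known", "first", "only" and "open" are said of these compounds alone.

The measured compounds:
In an assay on cells for displacement of a labelled ligand from prostaglandin E2 receptor EP4 subtype (Homo sapiens), read by scintillation counting (a higher number here means a weaker inhibitor, a lower number a stronger inhibitor), compound 1 `Cc1oc(C(=O)NS(=O)(=O)c2ccccc2)cc1COc1ccc(-c2ccccc2)cc1` gives 25 nM.
In this assay compound 2 `CC(C)c1oc(C(=O)O)cc1COc1ccc(-c2ccccc2)cc1` gives 3000 nM.
In this assay compound 3 `Cc1oc(C(=O)O)cc1COc1ccc(-c2ccccc2)cc1` gives 420 nM.

Compound 3 stands second highest of the three numbers. Its nearest neighbour is compound 2, separated by a 7.1-fold lower number from compound 2 to compound 3 (0.85 log units; beyond the scatter); its furthest is compound 1, separated by a 17-fold higher number from compound 1 to compound 3 (1.23 log units; beyond the scatter).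

Compound 4 `O=C(O)c1cc(COc2ccc(-c3ccccc3)cc2)co1` differs from compound 3 in one place: hydrogen in place of methyl on an aromatic carbon. Within the data shown here, of the measured steps, only the one from compound 2 to compound 3 bears on this change, since it also exchanges the group on that aromatic carbon for a smaller one; that step was a 7.1-fold lower number from compound 2 to compound 3 (0.85 log units; beyond the scatter). The step from compound 1 to compound 3, a 17-fold higher number from compound 1 to compound 3 (1.23 log units; beyond the scatter), concerns the carbonyl carbon and says nothing about the group on the aromatic carbon. Whether the movement toward smaller groups continues when the methyl is removed altogether cannot be read from a single step, so the expectation is a step of modest size or none beyond the scatter, if anything toward a lower number. Compound 4 is expected to give 300 nM, within a range of 100 nM to 900 nM, which would mean an estimated 1.4-fold lower number from compound 3 to compound 4 (0.15 log units; within the scatter).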

Compound 4, inhibition constant: 2000 nM
Beside the measured number, compound 4's estimate is 6.7-fold (0.82 log units) below it, and the stated range ends below it.
By their numbers in this assay, from the lowest: compound 1; then compound 3; then compounds 4 and 2 (each within the scatter of the next).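

In this assay, taking the methyl off the aromatic carbon next to the ring oxygen does not extend the trend seen from isopropyl to methyl but reverses it (a 4.8-fold higher number from compound 3 to compound 4 (0.68 log units; beyond the scatter)), so this position does not respond in one direction along the series isopropyl, methyl, hydrogen. Hydrogen and isopropyl at this place stand level (a 1.5-fold lower number from compound 2 to compound 4 (0.18 log units; within the scatter)), which leaves methyl, in compound 3, as the only one of the three groups whose number is set apart from both others, and shows that the methyl is not a replaceable detail on this carboxylic acid series. Nothing available here explains why methyl differs from the other two groups.

Going by these compounds, whether an ethyl group, a chlorine atom or a methoxy group on this aromatic carbon would match methyl, or pass it, remains open, so the range of groups that hold the lower number is not defined by these three points. Also open, on these data alone, is whether hydrogen or isopropyl in place of methyl would cost as much in compounds carrying the (phenylsulfonyl)amino group of compound 1.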